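The source may report more compounds than this note shows. Statements on the series, on what has been measured and on what is new or still open speak of the compounds shown alone.

Compound 1 `NS(=O)(=O)c1ccc(C/N=C/c2ccccc2OCc2cn(CCCOc3ccc4ccc(=O)oc4c3)nn2)cc1` carries the shared core with a plain aromatic ring at the position now of interest. In an ADME assay on HEK-293T cells (Homo sapiens) for cytotoxicity, read by MTT assay, with a stated time of 24 h (a higher number here means a weaker inhibitor, a lower number a stronger inhibitor), compound 1 gives 13900 nM, the lower of the two numbers recorded; its nearest neighbour is compound 2 `CCN(CC)c1ccc(/C=N/Cc2ccc(S(N)(=O)=O)cc2)c(OCc2cn(CCCOc3ccc4ccc(=O)oc4c3)nn2)c1`, which in this assay gives 29500 nM. Within the data shown here, the one measured step, a 2.1-fold higher number from compound 1 to compound 2 (0.33 log units; beyond the scatter), comes from putting diethylamino in place of hydrogen on an aromatic carbon. Compound 3 `NS(=O)(=O)c1ccc(C/N=C/c2cc(Br)ccc2OCc2cn(CCCOc3ccc4ccc(=O)oc4c3)nn2)cc1` differs from compound 1 in another way: bromo in place of hydrogen on an aromatic carbon. Among the measured compounds shown here, no measured step involves bromo, and the diethylamino step sits at a different place on the ring, so it bears only loosely on this change; it shows that a single substituent on this ring produced only a modest shift. A step of similar or smaller size is therefore expected, a 1.2-fold higher number from compound 1 to compound 3 (0.06 log units; within the scatter), possibly none beyond the scatter. Compound 3 is estimated at 16000 nM, within a range from 7000 nM to 36000 nM.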

Compound 3, half-maximal inhibitory concentration: 8250 nM
Beside the measured number, compound 3's estimate is 1.9-fold (0.29 log units) above it, and the stated range covers the measured number.
By their numbers in this assay, from the lowest: compounds 3 and 1 (each within the scatter of the next); then compound 2.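

In this assay, bromo in place of hydrogen on an aromatic carbon gives a 1.7-fold lower number from compound 1 to compound 3 (0.23 log units; within the scatter), so this single added atom, at a place meta to a large group and para to a large group, produces no difference that can be separated from the usual scatter. Among these compounds, until now the only measured step on this ring was the diethylamino change at a different place, so this is the first direct reading for this position, and it shows that a bromo group is tolerated here without a clear shift in the number. Nothing available explains this result. On these data alone, whether an amine, a carboxylic acid or a longer chain at this same place would give a step beyond the scatter stays open. Also open, as far as these compounds go, is how bromo would behave at the place that carries diethylamino in compound 2.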